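Swapping the Pyridine Amide on a Dimethylamino Analogue

The source may report more compounds than this note shows. Statements on the series, on what has been measured and on what is new or still open speak of the compounds shown alone.

Of the compounds shown here, three sharing one core have been tested in a functional assay on NCI-H1975 cells (Homo sapiens) for antiproliferative activity, read by MTT assay, with a stated time of 72 h; a higher number here means a weaker inhibitor, a lower number a stronger inhibitor. Compound 1 `COc1cc(F)c(NC(=O)c2ccnc(Cl)c2)cc1Nc1nccc(-c2cn(C)c3ccccc23)n1` gives 4330 nM. Compound 2 `COc1ccc(C(=O)Nc2cc(Nc3nccc(-c4cn(C)c5ccccc45)n3)c(OC)cc2F)nc1` gives 16800 nM. Compound 3 `COc1cc(N(C)C)c(NC(=O)c2ccnc(Cl)c2)cc1Nc1nccc(-c2cn(C)c3ccccc23)n1` gives 9200 nM; this number lies beyond the scatter from that of compound 1 but within the scatter of that of compound 2, so compound 3 and compound 2 cannot be ranked against each other on these data.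

Compound 4 `COc1ccc(C(=O)Nc2cc(Nc3nccc(-c4cn(C)c5ccccc45)n3)c(OC)cc2N(C)C)nc1` differs from compound 3 in one place: 5-methoxypyridin-2-yl in place of 2-chloropyridin-4-yl on a carbonyl carbon. The same exchange has been measured once before, on the partner bearing fluoro on the aromatic carbon, as a 3.9-fold higher number from compound 1 to compound 2 (0.59 log units; beyond the scatter). The other measured step, a 2.1-fold higher number from compound 1 to compound 3 (0.33 log units; beyond the scatter), shows the cost of the dimethylamino group itself but gives no information on whether that group alters the response to the amide exchange. With one precedent only, the expectation for compound 4 is that the step repeats at roughly the same size and in the same direction, toward a higher number, so a 3.9-fold higher number from compound 3 to compound 4 (0.59 log units; beyond the scatter) is expected. Compound 4 is therefore estimated at 36000 nM, with a range from 15000 nM to 80000 nM.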

Compound 4, half-maximal inhibitory concentration: 2130 nM
The estimate for compound 4 lay 17-fold (1.23 log units) above the measured number, and the stated range ends above it.
By their numbers in this assay, from the lowest: compound 4; then compound 1; then compounds 3 and 2 (each within the scatter of the next).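

In this assay, the exchange of 2-chloropyridin-4-yl for 5-methoxypyridin-2-yl on a carbonyl carbon gives a 4.3-fold lower number from compound 3 to compound 4 (0.64 log units; beyond the scatter) when dimethylamino is present, so the direction of this exchange depends on the group at the other site: the same change on two cores in this assay, a 3.9-fold higher number (0.59 log units; beyond the scatter) from compound 1 to compound 2 and a 4.3-fold lower number (0.64 log units; beyond the scatter) from compound 3 to compound 4, 17-fold (1.22 log units) apart, beyond the scatter of two such steps The reverse reading holds for the other change, since dimethylamino in place of fluoro raised the number on the 2-chloropyridin-4-yl amide but gives a 7.9-fold lower number from compound 2 to compound 4 (0.90 log units; beyond the scatter) on the 5-methoxypyridin-2-yl amide: the same change on two cores in this assay, a 2.1-fold higher number (0.33 log units; beyond the scatter) from compound 1 to compound 3 and a 7.9-fold lower number (0.90 log units; beyond the scatter) from compound 2 to compound 4, 17-fold (1.22 log units) apart, beyond the scatter of two such steps Across these four compounds the two sites therefore do not act independently, and the effect of either change can be stated only together with the group at the other site.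

The compounds shown leave open which part of the exchange drives this reversal, since the methoxy group, the loss of chlorine and the different point of attachment of the pyridine all change in a single step. They also leave open whether the reversal would persist with a plain pyridin-2-yl on the carbonyl carbon, or with another amine, such as 4-methylpiperazin-1-yl or a longer diamine chain, in place of dimethylamino.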